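The source may hold more compounds than are shown below. What is called first, only, known or untested is meant among the compounds shown, and "the series" means these compounds.

Measured compounds:
compound 1, `COc1ccc(Cc2nnc(CN(c3cccc(Cl)c3Cl)S(=O)(=O)c3ccc(C)cc3)o2)cc1`, 7.94 nM
compound 2, `COc1ccc(Cc2nnc(CN(c3cccc(Cl)c3Cl)S(=O)(=O)c3ccc(Cl)cc3)o2)cc1`, 20 nM
compound 3, `COc1ccc(Nc2nnc(CN(c3cccc(Cl)c3C)S(=O)(=O)c3ccc(C)cc3)o2)cc1`, 31.6 nM

All three were tested in an assay on CHO cells for displacement of a labelled ligand from prostaglandin E2 receptor EP1 subtype (Homo sapiens); a higher number here means a weaker inhibitor, a lower number a stronger inhibitor. Compound 1 and compound 2 share one core and differ only by chloro in place of methyl on an aromatic carbon; that change gave a 2.5-fold higher number from compound 1 to compound 2 (0.40 log units; beyond the scatter). Compound 3 has a different core, and the difference between the two cores is not broken down here. Compound 4, `COc1ccc(Nc2nnc(CN(c3cccc(Cl)c3Cl)S(=O)(=O)c3ccc(C)cc3)o2)cc1`, has not yet been measured; it arises from compound 3 by chloro in place of methyl on an aromatic carbon. Within the data shown here, this is the same kind of change as the one from compound 1 to compound 2, but its surroundings differ: in the earlier pair the place is para to a large group, here it is ortho to a chloro group and ortho to a large group. Since the earlier step weakened binding only modestly, a similar or smaller shift is expected here, so compound 4 is estimated at a 1.3-fold higher number from compound 3 to compound 4 (0.10 log units; within the scatter) relative to compound 3, resting on a 2.5-fold higher number from compound 1 to compound 2 (0.40 log units; beyond the scatter). The expected value for compound 4 is therefore 40 nM, between 15 nM and 110 nM.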

Compound 4, half-maximal inhibitory concentration: 39.8 nM
The estimate for compound 4 lay 1.0-fold (0.00 log units) above the measured number, and the stated range covers the measured number.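

Chloro in place of methyl gave a 1.3-fold higher number from compound 3 to compound 4 (0.10 log units; within the scatter) on this core, and the two cores do not separate the change: the same change on two cores in this assay, a 2.5-fold higher number (0.40 log units; beyond the scatter) from compound 1 to compound 2 and a 1.3-fold higher number (0.10 log units; within the scatter) from compound 3 to compound 4, 2.0-fold (0.30 log units) apart, within the scatter of two such steps. The change therefore carries over from the core of compound 1 to the core of compound 3 without a measurable difference, but two pairs cannot show that it would do so on a further core, and they give no reason for the size of either step. The other new step, a 5.0-fold higher number from compound 1 to compound 4 (0.70 log units; beyond the scatter) for (4-methoxyphenyl)amino in place of 4-methoxybenzyl, is a single pair, so it cannot yet show whether that change would carry over as well.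

The compounds shown leave open how a bromo, a trifluoromethyl or a methoxy group would read in place of the chloro on the 2,3-dichlorophenyl ring. They also leave open what an amide or a longer chain would do in place of the (4-methoxyphenyl)amino group.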